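A few compounds are considered here, and "the series" means these few. Any claim that something is new, unique, unknown or untested is made for them only; others in the source may bear on it.

Among the measured compounds shown here, compound 2 `CC1(C)CCC[C@]2(C)[C@@H](CC[C@@](C)(O)/C=C/c3cncc4ccccc34)[C@](C)(O)CC[C@@H]12` stands as the higher of the two numbers so far in a functional assay on PC-3 cells (Homo sapiens) for cytotoxicity, read by MTT assay, with a stated time of 48 h (a lower number here means a stronger inhibitor, a higher number a weaker inhibitor), where compound 2 gives 3900 nM, while compound 1 `Cc1ccc(C)c(/C=C/[C@](C)(O)CC[C@@H]2[C@@]3(C)CCCC(C)(C)[C@@H]3CC[C@@]2(C)O)c1` gives 176 nM. Compound 3 `COc1cccc(OC)c1/C=C/[C@](C)(O)CC[C@@H]1[C@@]2(C)CCCC(C)(C)[C@@H]2CC[C@@]1(C)O` differs from compound 2 by 2,6-dimethoxyphenyl in place of isoquinolin-4-yl on a double-bonded chain carbon bound to a double-bonded chain carbon. For the measured compounds named here, the one step that bears on this change is a 22-fold higher number from compound 1 to compound 2 (1.35 log units; beyond the scatter), in which a carbon-only aromatic ring was replaced by isoquinolin-4-yl at the same place. Returning to a carbon-only ring, here 2,6-dimethoxyphenyl, is therefore expected to lower the number again, roughly reversing that step, so compound 3 is estimated at 400 nM, within 120 nM to 1300 nM, a step of a 9.8-fold lower number from compound 2 to compound 3 (0.99 log units; beyond the scatter).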

Compound 3, half-maximal inhibitory concentration: 4000 nM
Compound 3: middle estimate off by 10-fold (1.00 log units), on the low side; measured number outside the range, above it.
By their numbers in this assay, from the lowest: compound 1; then compounds 2 and 3 (each within the scatter of the next).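

In this assay, the step of a 1.0-fold higher number from compound 2 to compound 3 (0.01 log units; within the scatter) shows that 2,6-dimethoxyphenyl and isoquinolin-4-yl cannot be told apart at this place, so a carbon-only aromatic ring is not enough by itself to give a low number. The step of a 23-fold higher number from compound 1 to compound 3 (1.36 log units; beyond the scatter) confirms this, and among these three compounds the low number belongs to 2,5-dimethylphenyl alone. Nothing available explains this difference.

Open, on these data alone, is how an unsubstituted phenyl would read on this chain carbon. Also open, as far as these compounds go, is whether a methoxy or methyl group alone, or an amine on the ring, would side with compound 1 or compound 3.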